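Swapping an Amide for a Urea: Expected Growth Inhibition

This account rests on a few compounds, and the source may have more. Where it says the series, first, only, none or still open, it means among the compounds named here.

Of the compounds shown here, two sharing one core have been measured. Compound 1 `COc1cc(-c2nn(-c3cccc(NC(=O)Nc4cc(C(F)(F)F)cc(C(F)(F)F)c4)c3)cc2-c2ccncc2)ccc1Cl` carries a urea bearing a 3,5-bis(trifluoromethyl)phenyl group, and in a functional assay on LOX IMVI cells (Homo sapiens) for inhibition, read by sulforhodamine B assay, with a stated time of 48 h (on this read-out lower numbers stand for stronger inhibition of growth and higher numbers for weaker inhibition of growth), compound 1 gives 783 nM. Compound 2 `COc1cc(-c2nn(-c3cccc(NC(=O)c4cccc(C(F)(F)F)c4)c3)cc2-c2ccncc2)ccc1Cl` instead carries an amide bearing a 3-(trifluoromethyl)phenyl group, and in this assay compound 2 gives 1390 nM. Compound 2 stands at the higher of the two numbers, but its gap to compound 1 lies within the usual scatter, so the two cannot be told apart.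

Compound 3 `COc1cc(-c2nn(-c3cccc(NC(=O)Nc4ccc(Cl)c(Cl)c4)c3)cc2-c2ccncc2)ccc1Cl` has not yet been measured. It differs from compound 2 in one place: (3,4-dichlorophenyl)amino in place of 3-(trifluoromethyl)phenyl on a carbonyl carbon. The amide thus becomes a urea, as in compound 1, with a different outer ring. Because compound 1, the measured urea, gives 783 nM, compound 3 is expected to land near that value. The step from compound 2 to compound 3 is therefore expected to be a 1.7-fold lower number from compound 2 to compound 3 (0.24 log units; within the scatter), a modest move toward stronger inhibition that may not clear the scatter. Compound 3 is estimated at 800 nM, with a range from 300 nM to 2200 nM.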

Compound 3, concentration for 50% growth inhibition: 954 nM
Compound 3: the middle estimate sits 1.2-fold (0.08 log units) below what was measured; the range from low to high includes it.
By their numbers in this assay, from the lowest: compounds 1, 3 and 2 (each within the scatter of the next).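

In this assay, putting (3,4-dichlorophenyl)amino in place of 3-(trifluoromethyl)phenyl on the carbonyl carbon gives a 1.5-fold lower number from compound 2 to compound 3 (0.16 log units; within the scatter), so this exchange of an amide for a urea with a different outer ring produces no difference that can be told from scatter. This single step alters two things at once, the linking group and the groups on the outer ring, and the result cannot divide any contribution between them. No measurement is available that would explain the outcome of this step.

The outer rings shown carry only chlorine or trifluoromethyl groups, so it remains open how a plain phenyl ring, or an outer ring bearing an amine or a carboxylic acid, would behave in this assay. Going by these compounds, the separate role of the linking group also remains open: that question needs an amide and a urea with the same outer ring, and a sulfonamide in the same place would extend the comparison.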